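Methyl in place of nitro on compound 1

The compounds below may be only part of what the source reports. "The series", "measured", "known", "first", "only" and "open" are said of these compounds alone.

In a functional assay on KYSE-450 cells (Homo sapiens) for inhibition, read by MTT assay, with a stated time of 48 h (a lower number here means a stronger inhibitor, a higher number a weaker inhibitor), compound 1 (`C/C=C/C(=O)N(Cc1ccc(OC)c([N+](=O)[O-])c1)c1cc(OC)c(OC)c(OC)c1`) gives 510 nM. Compound 3 (`C#CC(=O)N(Cc1ccc(OC)c(O)c1)c1cc(OC)c(OC)c(OC)c1`) gives 570 nM, within the scatter of compound 1, so these two together occupy the low end of the three numbers. Compound 2 (`COc1ccc(CNc2cc(OC)c(OC)c(OC)c2)cc1[N+](=O)[O-]`) stands well apart at 16800 nM.

Compound 4 (`C/C=C/C(=O)N(Cc1ccc(OC)c(C)c1)c1cc(OC)c(OC)c(OC)c1`) has not yet been measured. It differs from compound 1 in one place: methyl in place of nitro on an aromatic carbon, with methyl in place of nitro on an aromatic carbon.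

For the measured compounds named here, the only measured step is a 33-fold higher number from compound 1 to compound 2 (1.52 log units; beyond the scatter). It is large, but it concerns the (prop-1-en-1-yl)carbonyl on a nitrogen, not the aromatic carbon changed here, so its size does not carry over. Going by the values given here, no measured step covers the loss of nitro. Compound 3, at 570 nM, carries no nitro group, so a low number in this set does not depend on that group, although compound 3 differs from compound 1 in more than one place.

The expected change is small and upward, a 1.8-fold higher number from compound 1 to compound 4 (0.25 log units; within the scatter), and is not expected to lie clearly beyond the scatter. The estimate for compound 4 is 900 nM, with an expected range of 280 nM to 3500 nM.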

Compound 4, half-maximal inhibitory concentration: 32900 nM
Compound 4: the middle estimate sits 37-fold (1.56 log units) below what was measured, and the stated range ends below it.
By their numbers in this assay, from the lowest: compounds 1 and 3 (each within the scatter of the next); then compounds 2 and 4 (each within the scatter of the next).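

In this assay, the aromatic carbon ortho to a methoxy group proves highly sensitive to this change: methyl in place of nitro gives a 65-fold higher number from compound 1 to compound 4 (1.81 log units; beyond the scatter), a large step beyond the scatter. Compound 4 keeps the (prop-1-en-1-yl)carbonyl on the nitrogen, so that group alone does not secure a low number in this pair, and the change at the aromatic carbon is large, as is the step at the nitrogen, a 33-fold higher number from compound 1 to compound 2 (1.52 log units; beyond the scatter). No measurement at hand accounts for the step at this position.

With the rest of compound 1 held constant, the compounds shown compare only nitro and methyl at this carbon, so this one pair cannot tell whether nitro is specifically favourable or methyl specifically unfavourable. As far as these compounds go, how a nitrile, an amine or a carboxylic acid at the same carbon would read remains open, as does whether the same change would give a step of similar size with a different group on the nitrogen.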